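Fluoro to bromo in a small series

The source may hold more compounds than are shown below. What is called first, only, known or untested is meant among the compounds shown, and "the series" means these compounds.

For the measured compounds named here, in a functional assay on P388 cells (Mus musculus) (on this read-out lower numbers stand for stronger inhibition and higher numbers for weaker inhibition), three compounds sharing one core have numbers so far. Compound 1 (`Cc1ccc(/C=C/C(=O)Oc2ccc(/C=C3\CCCC(CN(C)C)C3=O)cc2)cc1`) gives 1290 nM and compound 2 (`COc1ccc(/C=C/C(=O)Oc2ccc(/C=C3\CCCC(CN(C)C)C3=O)cc2)cc1`) gives 2410 nM while compound 3 (`CN(C)CC1CCC/C(=C\c2ccc(OC(=O)/C=C/c3ccc(F)cc3)cc2)C1=O`) gives 4550 nM on the same scale. Compound 3 stands level with its nearest neighbour (a 1.9-fold higher number from compound 2 to compound 3 (0.28 log units; within the scatter)) and apart only from its furthest (a 3.5-fold higher number from compound 1 to compound 3 (0.55 log units; beyond the scatter)). The remaining step (a 1.9-fold higher number from compound 1 to compound 2 (0.27 log units; within the scatter)) changes methyl to methoxy at the same place.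

Compound 4 (`CN(C)CC1CCC/C(=C\c2ccc(OC(=O)/C=C/c3ccc(Br)cc3)cc2)C1=O`) has not yet been measured. It carries bromo in place of fluoro on an aromatic carbon of a six-membered aromatic ring of carbon only, para to a large group (bromo in place of fluoro on an aromatic carbon). Going by the values given here, no bromo compound has a number yet, so the guide is the two steps in which fluoro arrives at this place. Read in reverse, a 3.5-fold higher number from compound 1 to compound 3 (0.55 log units; beyond the scatter) and a 1.9-fold higher number from compound 2 to compound 3 (0.28 log units; within the scatter) suggest that a number falls when fluoro leaves for methyl or methoxy, so a small fall is expected here too. The expected move is a 1.8-fold lower number from compound 3 to compound 4 (0.26 log units; within the scatter) and this estimate carries real uncertainty. In this assay the estimate for compound 4 is 2500 nM and the expected range of 1100 nM to 5500 nM covers all three measured compounds.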

Compound 4, half-maximal inhibitory concentration: 4030 nM
Beside the measured number, compound 4's estimate is 1.6-fold (0.21 log units) below it; the range from low to high includes it.
By their numbers in this assay, from the lowest: compounds 1, 2, 4 and 3 (each within the scatter of the next, the first and the last beyond it).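

In this assay, exchanging one halogen for the other on this aromatic carbon, para to a large group, gives a 1.1-fold lower number from compound 3 to compound 4 (0.05 log units; within the scatter), so the two halogen compounds stand level and the small fall expected for bromo does not appear. Bromo also keeps the distance that fluoro showed from methyl, with a 3.1-fold higher number from compound 1 to compound 4 (0.49 log units; beyond the scatter), so among these compounds the methyl compound stands apart from both halogen compounds, while a 1.7-fold higher number from compound 2 to compound 4 (0.22 log units; within the scatter) leaves the methoxy compound, like its step to compound 3, inside the scatter and against any clean split into halogen and non-halogen groups. No accompanying measurement explains why the fluoro and bromo compounds stand level or why the methyl compound stands apart.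

The compounds shown do not tell how a bare hydrogen, chloro, a nitrile, trifluoromethyl or a hydroxyl at this place would compare with the methyl and halogen compounds. They also leave open whether the level result for fluoro and bromo would hold if the dimethylamino group on the shared core gave way to another amine, such as a piperidine.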